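A few compounds are considered here, and "the series" means these few. Any claim that something is new, unique, unknown or untested is made for them only; others in the source may bear on it.

Working notes on the series. The shared core of compound 1 `Cc1nnsc1CO/N=C/c1c(C)nn(C)c1Oc1ccccc1Cl` carries a 2-chlorophenyl on the ring oxygen. In a functional assay on PANC-1 cells (Homo sapiens) for inhibition, read by MTT assay, with a stated time of 48 h (a lower number here means a stronger inhibitor, a higher number a weaker inhibitor), compound 1 gives > 50000 nM, which is a limit of the assay and not a number. Compound 2 `Cc1nnsc1CO/N=C/c1c(C)nn(C)c1Oc1ccc(Br)cc1` carries a 4-bromophenyl on that oxygen instead, and in this assay compound 2 gives 12800 nM. Among the measured compounds shown here, the step of an at least 3.9-fold lower number from compound 1 to compound 2 (0.59 log units; beyond the scatter) is the single measured step in the set. For the measured compounds named here, compound 2 thus holds the only numerical value shown so far in this assay; compound 1 stands at a limit only.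

Compound 3 `Cc1nnsc1CO/N=C/c1c(C)nn(C)c1Oc1ccc(I)cc1` differs from compound 2 only in iodo in place of bromo on an aromatic carbon. Going by the values given here, no measured step exchanges bromo for iodo; the one step of an at least 3.9-fold lower number from compound 1 to compound 2 (0.59 log units; beyond the scatter) alters both the substituent and its pattern on the phenyl together, so it bears on the present change only loosely. A step in this assay not beyond the scatter is expected, with no clear direction. For compound 3 the expected step is a 1.2-fold lower number from compound 2 to compound 3 (0.07 log units; within the scatter). Compound 3 is estimated at 11000 nM in this assay, within 4500 nM to 30000 nM.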

Compound 3, half-maximal inhibitory concentration: > 50000 nM
Compound 3: only a limit was reported (the forecaster's own chance of this, stated with the estimate: 15%); at least 4.5-fold (0.65 log units) between middle value and limit.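

In this assay, iodo in place of bromo gives an at least 3.9-fold higher number from compound 2 to compound 3 (0.59 log units; beyond the scatter). The earlier step altered the substituent and its pattern on the phenyl together, whereas this one exchanges only the halogen at one place, so the exchange of bromo for iodo alone is enough to separate compound 2 from a limit reading. Compound 1 and compound 3 each carry a limit and not a number, so the step between them cannot be read, and compound 2 remains the only compound in the set with a number, the other two sitting at the same ceiling: the limit of > 50000 nM in this assay, at which 2 of the 3 values shown sit.

From the compounds shown here alone, how far the true value of compound 3 lies past its limit stays open, so the step from bromo to iodo has a known minimum size only. Also open, going by these compounds, is how a chloro, a fluoro, a methoxy or an amine at this same place on the phenyl would read in this assay, and so whether the bromo of compound 2 is a narrow optimum or one point on a broader trend.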